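A few compounds are considered here, and "the series" means these few. Any claim that something is new, unique, unknown or untested is made for them only; others in the source may bear on it.

Going by the values given here, in a functional assay on MIA PaCa-2 cells (Homo sapiens) for inhibition, read by MTT assay, with a stated time of 7 days (a lower number here means a stronger inhibitor, a higher number a weaker inhibitor), compound 2 (`CCN(CC)S(=O)(=O)c1ccc(S(=O)(=O)N2CCC[C@@H](C(=O)N3CCC(F)(F)CC3)C2)cc1`) gives 16 nM, the lower of the two numbers so far, while compound 1 (`CCN(CC)S(=O)(=O)c1ccc(S(=O)(=O)N2CCC[C@@H](C(=O)N3CCC(OC)CC3)C2)cc1`) gives 140 nM. Next comes compound 3 (`CCN(CC)S(=O)(=O)c1ccc(S(=O)(=O)N2CCC[C@@H](C(=O)N3CCC(C(F)F)CC3)C2)cc1`), with 4-(difluoromethyl)piperidin-1-yl in place of 4,4-difluoropiperidin-1-yl on a carbonyl carbon. Among the compounds with values here, the only measured step at this place, an 8.8-fold lower number from compound 1 to compound 2 (0.94 log units; beyond the scatter), is modest, and it shows that this assay can respond to a change here. Within the data shown here, no measured step covers this exact swap. The expected change is a 1.9-fold higher number from compound 2 to compound 3 (0.27 log units; within the scatter), a smaller move toward a higher number, though uncertain in size. Compound 3 is estimated at 30 nM, with an expected range of 8 nM to 110 nM.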

Compound 3, half-maximal inhibitory concentration: 420 nM
Compound 3: the middle estimate sits 14-fold (1.15 log units) below what was measured, and the stated range ends below it.
By their numbers in this assay, from the lowest: compound 2; then compound 1; then compound 3.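

In this assay this position proves far more sensitive than the earlier step showed: 4-(difluoromethyl)piperidin-1-yl in place of 4,4-difluoropiperidin-1-yl gives a 26-fold higher number from compound 2 to compound 3 (1.42 log units; beyond the scatter), so carrying two fluorines does not by itself preserve the low number. Difluoromethyl in place of methoxy on a saturated ring carbon gives a 3.0-fold higher number from compound 1 to compound 3 (0.48 log units; beyond the scatter), placing compound 3 highest of the three. Nothing measured bears on the cause of these steps. The compounds shown leave open whether the low number of compound 2 depends on both fluorines sitting directly on the ring. A single fluorine, two methyl groups or a trifluoromethyl group on that saturated ring carbon remains untested in the compounds shown here.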